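This account rests on a few compounds, and the source may have more. Where it says the series, first, only, none or still open, it means among the compounds named here.

In a functional assay on SK-OV-3 cells (Homo sapiens) for cytotoxicity, read by MTT assay, with a stated time of 48 h (on this read-out lower numbers stand for stronger inhibition and higher numbers for weaker inhibition), compound 1 `O=C(/C=C/c1ccc2c(c1)B(O)OC2)c1ccco1` gives 20700 nM, and compound 2 `O=C(/C=C/c1ccc2c(c1)B(O)OC2)c1ccc(Br)cc1` gives 4500 nM. Within the data shown here, the step of a 4.6-fold lower number from compound 1 to compound 2 (0.66 log units; beyond the scatter) is the only measured step, so compound 2 stands with the lowest number of the two measured compounds. Compound 3 `O=C(/C=C/c1ccc2c(c1)B(O)OC2)c1ccc(O)cc1` differs from compound 2 in one place: hydroxy in place of bromo on an aromatic carbon. Among the measured compounds shown here, no measured step covers this change, since the step from compound 1 to compound 2 swaps the whole group on the carbonyl carbon rather than one substituent on the benzene ring, so its size is only a loose guide to how much a single substituent swap can move the number. The step of a 1.8-fold higher number from compound 2 to compound 3 (0.25 log units; within the scatter) is therefore expected to be modest, with direction uncertain and a somewhat higher number judged slightly more likely. For compound 3 the expected value in this assay is 8000 nM, within a range of 2500 nM to 25000 nM.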

Compound 3, half-maximal inhibitory concentration: 13000 nM
Compound 3: middle estimate off by 1.6-fold (0.21 log units), on the low side, and the stated range covers the measured number.
By their numbers in this assay, from the lowest: compound 2; then compounds 3 and 1 (each within the scatter of the next).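

In this assay, the exchange of bromo for hydroxy on the aromatic carbon para to a large group gives a 2.9-fold higher number from compound 2 to compound 3 (0.46 log units; beyond the scatter), so changing this one substituent alone moves the number beyond the usual scatter. With hydroxy in that place, the change from furan-2-yl to 4-hydroxyphenyl gives only a 1.6-fold lower number from compound 1 to compound 3 (0.20 log units; within the scatter), so a phenyl group on the carbonyl carbon does not by itself separate these compounds, and the lower number of compound 2 goes with the 4-bromophenyl group among the three compounds shown. No evidence at hand explains the difference between bromo and hydroxy.

As far as these compounds go, it remains open where other groups at this place, such as an amine, a methoxy group or a carboxylic acid, would fall. From the compounds shown here alone, it is also open whether bromo would give a similar number elsewhere on the ring.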